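A few compounds are considered here, and "the series" means these few. Any claim that something is new, unique, unknown or untested is made for them only; others in the source may bear on it.

Measured so far:
- compound 1 `O=C(O)CC/C=C\CC1COC(c2ccco2)OC1c1cccnc1`: 1260 nM
- compound 2 `CC(C)(Oc1ccccc1)C1OCC(C/C=C\CCC(=O)O)C(c2cccnc2)O1`: 75.9 nM

Both numbers come from a functional assay for inhibition, with Homo sapiens as the target; on this read-out higher numbers stand for weaker binding and lower numbers for tighter binding. Going by the values given here, compound 2 gives the lowest of the two numbers; its only neighbour is compound 1, and the single measured step, a 17-fold lower number from compound 1 to compound 2 (1.22 log units; beyond the scatter), exchanged the whole group on the saturated ring carbon.

Compound 3 `CSc1ccccc1OC(C)(C)C1OCC(C/C=C\CCC(=O)O)C(c2cccnc2)O1` differs from compound 2 by methylsulfanyl in place of hydrogen on an aromatic carbon. Among the compounds with values here, no measured step touches this aromatic ring, so the one step known gives no guide to this change, and the expected step is a 1.3-fold lower number from compound 2 to compound 3 (0.10 log units; within the scatter), within the scatter. Compound 3 is expected to give 60 nM, with a range from 15 nM to 250 nM.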

Compound 3, dissociation constant: 89.1 nM
Compound 3: middle estimate off by 1.5-fold (0.17 log units), on the low side; measured number inside the range.
By their numbers in this assay, from the lowest: compounds 2 and 3 (each within the scatter of the next); then compound 1.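

On this aromatic carbon, ortho to a large group, methylsulfanyl in place of hydrogen gives in this assay a step of (a 1.2-fold higher number from compound 2 to compound 3 (0.07 log units; within the scatter)), so the two numbers cannot be told apart. Going by these compounds alone, this is the first measured change on this ring, and it shows that the two heavy atoms of methylsulfanyl can stand here with no step beyond the scatter. No measurement shown explains this result. From the compounds shown here alone, whether an amine or a longer chain on the same carbon would also stay within the scatter remains open.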